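The source may report more compounds than this note shows. Statements on the series, on what has been measured and on what is new or still open speak of the compounds shown alone.

Of the compounds shown here, three have been measured in a toxicity assay on the whole organism (J774 cells) for cytotoxicity, with Mus musculus as the target, read by MTT assay, with a stated time of 24 h, tested at 10 uM; a lower number here means a stronger effect, a higher number a weaker effect of the compound at the concentration tested. Compound 1, with the structure `CCCCCCCCCO[C@@H]1[C@@H](N)[C@@H](OCC(O)CNCCCO)O[C@H](CN)[C@H]1OCCCCCCCCC`, gives 89.9% in this assay, the highest of the three numbers. Compound 2, `C=CCO[C@H]1O[C@H](CN)[C@@H](OCc2ccc3ccccc3c2)[C@H](OCc2ccc3ccccc3c2)[C@H]1N`, gives 86.9% in this assay, which lies within the usual scatter of the number for compound 1. Compound 3, `CCCCCCCCCO[C@@H]1[C@@H](N)[C@@H](O[C@H]2[C@H](O)[C@@H](OCCCCCCCCC)[C@H](N)C[C@@H]2N)O[C@H](CN)[C@H]1O`, gives 78.4% in this assay, a number that sits beyond the scatter below that of compound 1. No two of these compounds differ from each other in a single place, so no single step can be read from them.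

Compound 4, `CCCCCCCCCO[C@@H]1[C@@H](N)[C@@H](OCC(O)CNCCN)O[C@H](CN)[C@H]1OCCCCCCCCC`, has not yet been measured in this assay. It differs from compound 1 in one place: amino in place of hydroxymethyl on a saturated chain carbon, two bonds along the chain from an amine nitrogen. Since the three measured values all sit at the weak end of the scale, and the change is small in what it counts, the step from compound 1 is expected to be small, at most a slight decrease, and the expected step is a number 4.9 percentage points lower from compound 1 to compound 4 (within the scatter). Compound 4 is therefore estimated to give 85% in this assay, with a range from 70% to 98%.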

Compound 4, a percentage reported as activity, at one concentration (the size of the read-out at that concentration, not a potency): 87.5%
For compound 4 the middle estimate is 2.5 percentage points below the measured one, within the range that was stated.
By their numbers in this assay, from the lowest: compounds 3, 2, 4 and 1 (each within the scatter of the next, the first and the last beyond it).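

Among these compounds, compound 4 gives the first step in this set that can be read at a single place: in this assay, amino in place of hydroxymethyl on a saturated chain carbon, two bonds along the chain from an amine nitrogen, amounts to a number 2.4 percentage points lower from compound 1 to compound 4 (within the scatter). At this position, then, the exchange of (3-hydroxypropyl)amino for (2-aminoethyl)amino does not separate the two compounds at the concentration tested. Nothing measured on these compounds gives a reason for this result.

Going by these compounds, it remains open whether a carboxylic acid, a guanidine or a longer chain ending in an amine at this place would stay as close to compound 1. A reading at one concentration also leaves open whether compound 1 and compound 4 would still not separate at other concentrations.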